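Swapping the Oxane Ring for a Pyrrolidine

This account rests on a few compounds, and the source may have more. Where it says the series, first, only, none or still open, it means among the compounds named here.

Compound 2 `Nc1ncnc2c1c(Oc1cccc(Cl)c1)nn2CC1CCOCC1` was tested in an ADME assay on microsomes from liver (Rattus norvegicus) for metabolic stability, read by LC-MS, tested at 1 uM (a lower number here means that the compound disappears faster, a higher number that the compound lasts longer), and gives 0.233 h. Of the two plain numbers recorded, this is the higher one; compound 3 `Cc1cccc(Oc2nn(C(C)(C)C)c3ncnc(N)c23)c1` gives 0.07 h in this assay. Compound 1 `Nc1ncnc2c1c(Oc1cccc(Cl)c1)nn2CC1CCNCC1` gives only a limit of the assay, > 1 h. Among the compounds with values here, the one step that can be sized is an at least 4.2-fold lower number from compound 1 to compound 2 (0.63 log units; beyond the scatter), and its starting point is a limit, (the limit of > 1 h in this assay, at which 1 of the 3 values shown sits).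

The change to compound 4 `Nc1ncnc2c1c(Oc1cccc(Cl)c1)nn2CC1CCNC1` is pyrrolidin-3-yl in place of oxan-4-yl on a saturated chain carbon bound to an aromatic nitrogen. This runs the measured step backwards in kind: oxan-4-yl is again replaced, and pyrrolidin-3-yl, like piperidin-4-yl, carries one hydrogen-bond donor where oxan-4-yl has none. Since the piperidin-4-yl compound lasted beyond the limit while the oxan-4-yl compound did not, a rise beyond the scatter is expected on returning to a nitrogen-containing ring, though the smaller ring leaves the exact size uncertain. Compound 4 is therefore expected to show a 3.9-fold higher number from compound 2 to compound 4 (0.59 log units; beyond the scatter). The estimate for compound 4 is 0.9 h, with a range from 0.3 h to 2.5 h, and the value may again reach the limit.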

Compound 4, half-life: > 1 h
Compound 4 gave a limit, no number; the forecaster's own chance of this, stated with the estimate: 40%; middle value at least 1.1-fold (0.04 log units) from the limit.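

In this assay there is an at least 4.2-fold higher number from compound 2 to compound 4 (0.63 log units; beyond the scatter), so the rise seen on leaving oxan-4-yl is not confined to piperidin-4-yl: the five-membered pyrrolidin-3-yl ring gives it too. Among compound 1, compound 2 and compound 4, which differ only in this ring, both rings with a nitrogen now stand apart from the ring with an oxygen, and none of these compounds goes against that pattern. Compound 4 gives a limit and not a number, as does compound 1, so the step between them cannot be read: the limit of > 1 h in this assay, at which 2 of the 4 values shown sit.

Going by these compounds, how far either nitrogen ring lies past that limit stays open. Also open, on these data alone, is whether the hydrogen on the ring nitrogen matters, which a ring nitrogen carrying a methyl group or an acetyl group would test.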